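From a Butyl to a Dienyl Chain on the Carbonyl

This account rests on a few compounds, and the source may have more. Where it says the series, first, only, none or still open, it means among the compounds named here.

- Compound 1 `CCCCC(=O)N(Cc1ccc(OC)c(O)c1)c1cc(OC)c(OC)c(OC)c1` gives 300 nM
- Compound 2 `COc1cc(NCc2ccc(Br)cc2)cc(OC)c1OC` gives > 80000 nM as a limit

Within the data shown here, in a functional assay on KYSE-450 cells (Homo sapiens) for inhibition, read by MTT assay, with a stated time of 48 h (a lower number here means a stronger inhibitor, a higher number a weaker inhibitor), compound 1 gives 300 nM and so far holds the only plain number in the set. Compound 2 gives > 80000 nM as a limit of the assay and not as a number.

Attention now turns to compound 3 `C/C=C/C=C/C(=O)N(Cc1ccc(OC)c(O)c1)c1cc(OC)c(OC)c(OC)c1` which keeps the core of compound 1 and changes only the chain on the carbonyl. The change is penta-1,3-dien-1-yl in place of butyl on a carbonyl carbon with penta-1,3-dien-1-yl in place of butyl on a carbonyl carbon. Among the measured compounds shown here, no measured pair in the set shows what a change of this kind does in this assay and the expectation therefore starts from compound 1 at 300 nM alone. With so little to go on, no direction is favoured, and the estimated step of a 1.2-fold higher number from compound 1 to compound 3 (0.07 log units; within the scatter) is expected to stay within the usual scatter. Compound 3 is expected at 350 nM with an estimated range of 90 nM to 1400 nM in the same read-out.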

Compound 3, half-maximal inhibitory concentration: 180 nM
Compound 3: middle estimate off by 1.9-fold (0.29 log units), on the high side; the measured number falls inside the stated range.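

Across the change of chain on the carbonyl carbon, with penta-1,3-dien-1-yl in place of butyl, this assay gives a 1.7-fold lower number from compound 1 to compound 3 (0.22 log units; within the scatter) and so does not separate the two compounds. This first measured pair at this place shows that, with the rest of the core of compound 1 unchanged, a chain with two double bonds outside aromatic rings reads the same within the scatter as the saturated butyl chain. No measured property at hand bears on this result, and the pair gives no explanation for it.

With only one pair at this place, the effects of the double bonds and of the chain length cannot be told apart, and a pentyl chain on the same carbonyl carbon would be the direct comparison, but none is among the compounds shown. From the compounds shown here alone, how far the place accepts other kinds of group also stays open, for a longer chain, a phenyl ring, or a chain ending in an amine or a carboxylic acid are likewise absent from the set.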